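Chain length in the propargylamine-coumarin series

The source may report more compounds than this note shows. Statements on the series, on what has been measured and on what is new or still open speak of the compounds shown alone.

Working notes. In an assay on isolated protein for inhibition of Amine oxidase [flavin-containing] B (Homo sapiens), read by fluorescence and Amplex Red, with stated times of 15 min and 20 min (a lower number here means a stronger inhibitor, a higher number a weaker inhibitor), compound 3 `C#CCN(C)CCCOc1ccc2ccc(=O)oc2c1` gives 1090 nM. Compound 2 `C#CCN(CCCCOc1ccc2ccc(=O)oc2c1)Cc1cccc(F)c1` gives 1550 nM, a gap within the scatter of compound 3; compound 1 `C#CCN(CCCCOc1ccc2ccc(=O)oc2c1)Cc1cccc(OC)c1` gives 2340 nM, a gap beyond the scatter. For the measured compounds named here, the only measured step, a 1.5-fold lower number from compound 1 to compound 2 (0.18 log units; within the scatter), concerns the aromatic substituent and does not bear on the chain. Going by the values given here, compound 4 `C#CCN(C)CCCCOc1ccc2ccc(=O)oc2c1` differs from compound 3 by (methyl(propargyl)amino)methyl in place of methyl(propargyl)amino on a saturated chain carbon, three bonds along the chain from an oxygen on an aromatic ring; no measured pair isolates this change, since compound 1 and compound 2 carry the longer chain together with a different amine substituent. With nothing pointing either way, the expected step in this assay, a 1.1-fold lower number from compound 3 to compound 4 (0.06 log units; within the scatter), lies within the scatter. Compound 4 is therefore estimated at 950 nM, between 400 nM and 2500 nM.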

Compound 4, half-maximal inhibitory concentration: 27 nM
Estimate against measurement, compound 4: 35-fold (1.55 log units) above; the whole stated range lies above it.
By their numbers in this assay, from the lowest: compound 4; then compounds 3, 2 and 1 (each within the scatter of the next, the first and the last beyond it).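

In this assay the chain position proves far more sensitive than the aromatic substituent: (methyl(propargyl)amino)methyl in place of methyl(propargyl)amino gives a large step (a 40-fold lower number from compound 3 to compound 4 (1.61 log units; beyond the scatter)). At the same chain length, the amine substituent also matters, with hydrogen in place of 3-fluorophenyl (a 57-fold lower number from compound 2 to compound 4 (1.76 log units; beyond the scatter)) or 3-methoxyphenyl (an 87-fold lower number from compound 1 to compound 4 (1.94 log units; beyond the scatter)) on the saturated chain carbon bound to an amine nitrogen giving large steps. Nothing measured here explains either change.

Still open, on these data alone, is whether a longer chain than that of compound 4 keeps this level. Also open, as far as these compounds go, is whether an ethyl group can replace the methyl on the amine.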